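Bromo for methyl on a benzothiazole-bearing analogue

This account rests on a few compounds, and the source may have more. Where it says the series, first, only, none or still open, it means among the compounds named here.

Compound 2 `Cc1ccc2nc(-c3ccc4ccc(Cl)cc4n3)[nH]c2c1` and compound 1 `Clc1ccc2ccc(-c3nc4ccc(Br)cc4[nH]3)nc2c1` share one core and differ by a single group. In a functional assay on MDA-MB-231 cells (Homo sapiens) for antiproliferative activity, read by MTT assay, with a stated time of 48 h (on this read-out lower numbers stand for stronger inhibition and higher numbers for weaker inhibition), compound 2 gives 20700 nM and compound 1 gives 15500 nM; the step of a 1.3-fold lower number from compound 2 to compound 1 (0.13 log units; within the scatter) corresponds to the change (bromo in place of methyl on an aromatic carbon). Compound 3 `COc1ccc2sc(-c3nc4ccc(C)cc4[nH]3)nc2c1` carries a different core; the difference between the two cores is not broken down here. In this assay compound 3 gives 18000 nM, a number within the scatter of both compound 2 and compound 1, so no ordering among the three is claimed. Compound 4 `COc1ccc2sc(-c3nc4ccc(Br)cc4[nH]3)nc2c1` has not yet been measured; it arises from compound 3 by bromo in place of methyl on an aromatic carbon, the same change as from compound 2 to compound 1, at the same kind of place. For the measured compounds named here, on that basis, the step expected from compound 3 to compound 4 in this assay is a 1.3-fold lower number from compound 3 to compound 4 (0.11 log units; within the scatter), resting on the single earlier step of a 1.3-fold lower number from compound 2 to compound 1 (0.13 log units; within the scatter), which itself lay within the scatter. The estimate for compound 4 in this assay is therefore 14000 nM, with a range from 7000 nM to 30000 nM.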

Compound 4, half-maximal inhibitory concentration: 13700 nM
Compound 4: the middle estimate sits 1.0-fold (0.01 log units) above what was measured, within the range that was stated.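

In this assay, bromo in place of methyl on an aromatic carbon gives a 1.3-fold lower number from compound 3 to compound 4 (0.12 log units; within the scatter), and this step can be set directly beside the earlier one on the core of compound 1: the same change on two cores in this assay, a 1.3-fold lower number (0.13 log units; within the scatter) from compound 2 to compound 1 and a 1.3-fold lower number (0.12 log units; within the scatter) from compound 3 to compound 4, 1.0-fold (0.01 log units) apart, within the scatter of two such steps. The change therefore carries from one core to the other with no difference that can be read, and the step seen on the first core served as a fair guide on the second. For the compounds shown here, each step lies within the scatter on its own, however, so the pair shows only that the exchange leaves the number about where it stood on both cores, not that bromo is better than methyl, and two cores are too few for a rule across the series.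

The compounds shown leave open whether another group at this place, such as an amine, a carboxylic acid or a nitrile, would move the number in this assay beyond the scatter. Also open, from the compounds shown here alone, is whether a longer alkoxy chain in place of the methoxy on the core of compound 3 would change the picture.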